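This account rests on a few compounds, and the source may have more. Where it says the series, first, only, none or still open, it means among the compounds named here.

Measured compounds in a functional assay on HeLa cells (Homo sapiens) for cytotoxicity, read by MTT assay, with a stated time of 72 h; on this read-out lower numbers stand for an effect already at smaller amounts and higher numbers for an effect only at larger amounts of compound:
- compound 1 `CCS[C@@H]1[C@H](SCC)[C@@H](Cn2cc(-c3ccccc3)nn2)O[C@H]1n1ccc(=O)[nH]c1=O`; in this assay compound 1 gives 6590 nM
- compound 2 `CCOC(=O)c1cn(C[C@H]2O[C@@H](n3ccc(=O)[nH]c3=O)[C@H](SCC)[C@@H]2SCC)nn1`; in this assay compound 2 reaches only a limit, >= 100000 nM

Compound 1 holds the only real number shown, since the other value is a limit, (the limit of >= 100000 nM in this assay, at which 1 of the 2 values shown sits). Among the measured compounds shown here, the one measured step, an at least 15-fold higher number from compound 1 to compound 2 (1.18 log units; beyond the scatter), swaps a group on the aromatic carbon of the triazole, which is not the part altered here.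

Compound 3 `CCS[C@@H]1[C@H](SCC)[C@@H](Cn2cc(-c3ccccc3)nn2)O[C@H]1n1ccc(N)nc1=O` differs from compound 1 in this way: a group of 8 heavy atoms (4 carbon, 3 nitrogen, 1 oxygen; one six-membered aromatic ring with 2 hetero atoms) in place of a group of 8 heavy atoms (4 carbon, 2 nitrogen, 2 oxygen; one six-membered aromatic ring with 2 hetero atoms), on a saturated ring carbon. For the measured compounds named here, no measured step touches this part of the shared core, so nothing among the measured compounds tells how large a change to expect. Without such guidance, compound 3 is expected to sit near compound 1, with the step of a 1.5-fold higher number from compound 1 to compound 3 (0.18 log units; within the scatter) estimated to lie within the scatter or a little beyond it. The estimate for compound 3 in this assay is 10000 nM, with a range from 2500 nM to 40000 nM.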

Compound 3, half-maximal effective concentration: 33500 nM
Estimate against measurement, compound 3: 3.4-fold (0.53 log units) below, within the range that was stated.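

Among the compounds shown here, compound 3 gives the first reading at this position, on the saturated ring carbon next to the ring oxygen. In this assay, replacing one six-membered aromatic ring with 2 hetero atoms by another of the same heavy-atom count gives a 5.1-fold higher number from compound 1 to compound 3 (0.71 log units; beyond the scatter). The position therefore responds to change, even when the entering group matches the leaving one in size and ring type, and nothing measured here explains the shift.

From the compounds shown here alone, whether a methyl group on this ring, or adenine in its place, would give a lower or a higher number stays open. Going by these compounds, it is also open whether the effect of this exchange would hold with ethoxycarbonyl in place of phenyl, since compound 1 and compound 3 show it only with phenyl.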